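Nitro to Methoxy: Expected Gain in Cytotoxicity

The source may report more compounds than this note shows. Statements on the series, on what has been measured and on what is new or still open speak of the compounds shown alone.

Three measured compounds share one core. Compound 1 `COc1cc2c(Oc3ccc(NC(=O)c4nn(-c5ccccc5)c(=O)c5ccccc45)cc3F)ccnc2cc1OCCCN1CCCC1` gives 530 nM in a functional assay on MKN-45 cells (Homo sapiens) for cytotoxicity, read by MTT assay, with a stated time of 72 h; a higher number here means a weaker inhibitor, a lower number a stronger inhibitor. Compound 2 `COc1cc2c(Oc3ccc(NC(=O)c4nn(-c5ccc(Br)cc5)c(=O)c5ccccc45)cc3F)ccnc2cc1OCCCN1CCCC1` gives 230 nM in this assay, and compound 3 `COc1cc2c(Oc3ccc(NC(=O)c4nn(-c5ccc([N+](=O)[O-])cc5)c(=O)c5ccccc45)cc3F)ccnc2cc1OCCCN1CCCC1` gives 1620 nM, the highest of the three numbers. The steps between them are modest but beyond the scatter: bromo in place of hydrogen gave a 2.3-fold lower number from compound 1 to compound 2 (0.36 log units; beyond the scatter), nitro in place of hydrogen gave a 3.1-fold higher number from compound 1 to compound 3 (0.49 log units; beyond the scatter), and nitro in place of bromo gave a 7.0-fold higher number from compound 2 to compound 3 (0.85 log units; beyond the scatter). Compound 4 `COc1ccc(-n2nc(C(=O)Nc3ccc(Oc4ccnc5cc(OCCCN6CCCC6)c(OC)cc45)c(F)c3)c3ccccc3c2=O)cc1` differs from compound 3 by methoxy in place of nitro on an aromatic carbon. For the measured compounds named here, no measured step introduces a methoxy, so the steps that bear on this change are the two that install the nitro, both of which raised the number; removing it is expected to lower the number again. The hydrogen analogue compound 1 gave 530 nM and the bromo analogue compound 2 gave 230 nM, and the methoxy compound is expected to land between them. Compound 4 is therefore expected to show a step of a 4.1-fold lower number from compound 3 to compound 4 (0.61 log units; beyond the scatter). The estimate for compound 4 is 400 nM, with a range from 150 nM to 1100 nM.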

Compound 4, half-maximal inhibitory concentration: 1320 nM
Compound 4: middle estimate off by 3.3-fold (0.52 log units), on the low side; the measured number lies above the stated range.
By their numbers in this assay, from the lowest: compound 2; then compound 1; then compounds 4 and 3 (each within the scatter of the next).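

In this assay, taking out the nitro did not by itself recover the lost ground, since methoxy at this position gave a 1.2-fold lower number from compound 3 to compound 4 (0.09 log units; within the scatter). Methoxy in place of hydrogen gave a 2.5-fold higher number from compound 1 to compound 4 (0.40 log units; beyond the scatter), so this group stands on the same side of the hydrogen compound as the nitro, and the two cannot be told apart here. Methoxy in place of bromo gave a 5.7-fold higher number from compound 2 to compound 4 (0.76 log units; beyond the scatter), which leaves the bromo compound as the only one of the four with a number lower than that of the hydrogen compound.

The compounds shown leave open whether an amine, a carboxylic acid or a longer alkoxy chain on this carbon would read like the bromo compound or like the nitro and methoxy compounds. Nothing shown gives a reason for the gap between bromo and these two groups.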